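The source may report more compounds than this note shows. Statements on the series, on what has been measured and on what is new or still open speak of the compounds shown alone.

Of the compounds shown here, three built on a shared core have been tested in a functional assay on OVCAR cells (Homo sapiens) for cytotoxicity, read by sulforhodamine B assay, with a stated time of 48 h; on this read-out lower numbers stand for stronger inhibition and higher numbers for weaker inhibition. Compound 1 `CC(=O)N1N=C(c2ccc(Br)cc2)CC1c1cccc(Cl)c1Cl` gives 39800 nM, and compound 2 `CC(=O)N1N=C(c2ccco2)CC1c1ccc(Br)cc1` gives 18900 nM. Compound 3 `O=CCN1N=C(c2ccc3ccccc3c2)CC1c1ccccc1[N+](=O)[O-]` gives 3480 nM, the lowest of the three numbers; its gaps to compound 2 and to compound 1 both lie beyond the usual scatter, so compound 3 is the most potent of the measured set. Compound 4 `COc1ccc(C2CC(c3ccc4ccccc4c3)=NN2CC=O)cc1` has not yet been measured. It differs from compound 3 in one place: 4-methoxyphenyl in place of 2-nitrophenyl on a saturated ring carbon. Within the data shown here, no measured pair shows a swap of this kind, so the direction is uncertain; a modest weakening is expected, and the expected step is a 1.7-fold higher number from compound 3 to compound 4 (0.24 log units; within the scatter). Compound 4 is therefore estimated at 6000 nM, within a range from 1800 nM to 20000 nM.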

Compound 4, half-maximal inhibitory concentration: 5790 nM
The estimate for compound 4 lay 1.0-fold (0.02 log units) above the measured number, within the range that was stated.
By their numbers in this assay, from the lowest: compounds 3 and 4 (each within the scatter of the next); then compound 2; then compound 1.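

In this assay the swap on this saturated ring carbon gives a 1.7-fold higher number from compound 3 to compound 4 (0.22 log units; within the scatter), so 4-methoxyphenyl and 2-nitrophenyl cannot be told apart here, and the nitro group is not required for the activity of compound 3. Among these compounds, this is the first pair in the set that differs in one place. Nothing measured here bears on the reason for this result. The compounds shown leave open how a plain phenyl, or a phenyl carrying an amine or a carboxylic acid, would read on this carbon. They also cannot separate the identity of the ring's substituent from where it sits.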